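Swapping the benzyl substituent and watching metabolic stability

A few compounds are considered here, and "the series" means these few. Any claim that something is new, unique, unknown or untested is made for them only; others in the source may bear on it.

Compound 1 `Cc1cc(S(=O)(=O)/N=C(\N)n2nccc2-c2ccccc2)c(SCc2ccccc2Cl)cc1Cl` is a sulfonyl guanidine whose core carries a chlorobenzyl sulfide. In an ADME assay on microsomes from liver (Homo sapiens) for metabolic stability, read by LC-MS, using NADPH, tested at 5 uM (on this read-out higher numbers stand for a longer-lived compound and lower numbers for a shorter-lived compound), compound 1 gives 0.226 h. Within the data shown here, its only measured neighbour is compound 2 `Cc1cc(-c2ccccc2)n(/C(N)=N/S(=O)(=O)c2cc(C)c(Cl)cc2SCc2ccccc2Cl)n1`, which in this assay gives 0.163 h; the difference, a 1.4-fold lower number from compound 1 to compound 2 (0.14 log units; within the scatter), comes from a methyl in place of hydrogen on an aromatic carbon, so compound 1 stands alongside compound 2 rather than apart from it.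

Compound 3 `Cc1cc(S(=O)(=O)/N=C(\N)n2nccc2-c2ccccc2)c(SCc2cccc(C(F)(F)F)c2)cc1Cl` differs from compound 1 in a different place: 3-(trifluoromethyl)phenyl in place of 2-chlorophenyl on a saturated chain carbon bound to a sulfur. Among the measured compounds shown here, no measured step touches this part of the molecule, and the single step available, from compound 1 to compound 2, was within the scatter. With nothing to point either way, the expected step of a 1.0-fold lower number from compound 1 to compound 3 (0.01 log units; within the scatter) is none beyond the scatter. Compound 3 is therefore estimated at 0.22 h in this assay, with a range from 0.1 h to 0.5 h.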

Compound 3, half-life: 0.0863 h
Compound 3: the middle estimate sits 2.5-fold (0.41 log units) above what was measured; the measured number lies below the stated range.
By their numbers in this assay, from the lowest: compounds 3, 2 and 1 (each within the scatter of the next, the first and the last beyond it).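

The group on the saturated chain carbon bound to a sulfur can change the result in this assay: 3-(trifluoromethyl)phenyl in place of 2-chlorophenyl gives a 2.6-fold lower number from compound 1 to compound 3 (0.42 log units; beyond the scatter). This is the only step shown that lies beyond the scatter, so this part of the molecule can shift the half-life, although the step is modest. Nothing available explains why the half-life shortens with this swap.

The change replaces the chlorine with trifluoromethyl and also alters the ring position named in each group, so the compounds shown cannot separate those two differences. As far as these compounds go, it also remains open how this assay would respond to a phenyl ring carrying an amine or a carboxylic acid, or to a longer chain in place of the benzyl group.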